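The source may report more compounds than this note shows. Statements on the series, on what has been measured and on what is new or still open speak of the compounds shown alone.

In an assay for inhibition of mitogen-activated protein kinase kinase kinase 14 (Homo sapiens), read by luminescence and ADP-Glo, with a stated time of 120 min, in the presence of a further agent that is not named here (a lower number here means a stronger inhibitor, a higher number a weaker inhibitor), compound 1 `CC(O)(C#Cc1cccc(Nc2ncnc3[nH]ccc23)c1)c1nccs1` gives 1640 nM. Compound 2 `CN(C)c1ccc(C#CC(C)(O)c2nccs2)cc1Nc1ncnc2[nH]ccc12` gives 22.5 nM, and compound 3 `CC(O)(C#Cc1ccc(N2CCNCC2)c(Nc2ncnc3[nH]ccc23)c1)c1nccs1` gives 47.9 nM, the second highest of the three numbers, closest to compound 2 and far from compound 1. The steps of a 73-fold lower number from compound 1 to compound 2 (1.86 log units; beyond the scatter) and a 34-fold lower number from compound 1 to compound 3 (1.53 log units; beyond the scatter) are both large, whereas the step of a 2.1-fold higher number from compound 2 to compound 3 (0.33 log units; beyond the scatter) is modest. Compound 4 `C[C@@H]1CN(c2ccc(C#CC(C)(O)c3nccs3)cc2Nc2ncnc3[nH]ccc23)CCN1` differs from compound 3 by methyl in place of hydrogen on a saturated ring carbon. Within the data shown here, no measured step alters the six-membered non-aromatic ring itself; the closest comparison, a 2.1-fold higher number from compound 2 to compound 3 (0.33 log units; beyond the scatter), shows that exchanging the entire amine group shifts this assay only modestly, so a methyl on the ring is expected to give a change of no more than the scatter, in either direction. Compound 4 is therefore estimated at 45 nM in this assay, between 15 nM and 130 nM, which is expected to be a 1.1-fold lower number from compound 3 to compound 4 (0.03 log units; within the scatter).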

Compound 4, half-maximal inhibitory concentration: 210 nM
Compound 4: middle estimate off by 4.7-fold (0.67 log units), on the low side; measured number above the stated range.
By their numbers in this assay, from the lowest: compound 2; then compound 3; then compound 4; then compound 1.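

In this assay, this saturated ring carbon proves sensitive to a single methyl, which gives a 4.4-fold higher number from compound 3 to compound 4 (0.64 log units; beyond the scatter), more than the exchange of the entire amine group did in a 2.1-fold higher number from compound 2 to compound 3 (0.33 log units; beyond the scatter). The 3-methylpiperazin-1-yl group keeps part of the gain over hydrogen on the aromatic carbon, with a 7.8-fold lower number from compound 1 to compound 4 (0.89 log units; beyond the scatter), yet it falls behind dimethylamino, with a 9.3-fold higher number from compound 2 to compound 4 (0.97 log units; beyond the scatter). No measurement given here explains this shift. Going by these compounds, it remains open whether the opposite methyl configuration, an ethyl group on the same ring carbon, or a methyl on the other ring nitrogen would behave alike.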